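Swapping the aryl ketone substituent in a pyrazole chalcone pair

The compounds below may be only part of what the source reports. "The series", "measured", "known", "first", "only" and "open" are said of these compounds alone.

Measured so far:
Compound 1, `COc1cc(-c2cc(/C=C/C(=O)c3ccc(N)cc3)[nH]n2)cc(OC)c1OC`: -77%
Compound 2, `COc1ccc(C(=O)/C=C/c2cc(-c3cc(OC)c(OC)c(OC)c3)n[nH]2)cc1`: 19%

Both compounds were tested in a functional assay on MDA-MB-231 cells (Homo sapiens) for cytotoxicity, read by sulforhodamine B assay, with a stated time of 48 h, tested at 100 uM; a higher number here means a weaker effect of the compound at the concentration tested, a lower number a stronger effect. Compound 2 gives the higher of the two numbers, so it is the weaker of the pair: the step of a number 96 percentage points higher from compound 1 to compound 2 (beyond the scatter) shows how much the read-out moved when the amino group was exchanged for methoxy.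

Compound 3, `COc1cc(-c2cc(/C=C/C(=O)c3ccc(F)c(F)c3)[nH]n2)cc(OC)c1OC`, has not yet been measured. It differs from compound 2 by 3,4-difluorophenyl in place of 4-methoxyphenyl on a carbonyl carbon. For the measured compounds named here, no measured step covers this exact exchange, so nothing says in which direction the number will move. Going by the values given here, the one step that touches the same position, from compound 1 to compound 2, was large, which suggests that what sits on that ring can shift the read-out strongly in either direction. For compound 3 the estimate is therefore a broad one centred near 0%, spanning -60% to 50%, meaning an expected step of a number 19 percentage points lower from compound 2 to compound 3 (beyond the scatter).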

Compound 3, a percentage reported as activity, at one concentration (the size of the read-out at that concentration, not a potency): -49%
Beside the measured number, compound 3's estimate is 49 percentage points above it; measured number inside the range.
By their numbers in this assay, from the lowest: compound 1; then compound 3; then compound 2.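

In this assay, 3,4-difluorophenyl in place of 4-methoxyphenyl on the carbonyl carbon gives a number 68 percentage points lower from compound 2 to compound 3 (beyond the scatter) and so shows that a strong effect at this position does not depend on the amino group of compound 1. A gap to that compound remains, however, as 3,4-difluorophenyl in place of 4-aminophenyl gives a number 28 percentage points higher from compound 1 to compound 3 (beyond the scatter) and leaves compound 1 the strongest of the three and compound 2 the weakest. Nothing available explains this order.

The compounds shown leave open whether one fluorine, as in a 4-fluorophenyl group, would do as much as the two in compound 3. They also leave open whether a 4-hydroxyphenyl or 4-dimethylaminophenyl group would come closer to 4-aminophenyl.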